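The source may report more compounds than this note shows. Statements on the series, on what has been measured and on what is new or still open speak of the compounds shown alone.

Measured so far (in an ADME assay on MDCKII-LE cells (Canis lupus familiaris) for permeability, read by transwell migration, in the apical to basolateral direction; on this read-out lower numbers stand for lower permeability and higher numbers for higher permeability):

- compound 1 `CC1(C)C[C@H](CN([C@H](CCC(F)(F)F)C(N)=O)S(=O)(=O)c2ccc(Cl)cc2)O1` gives 18.1 10^-6 cm/s
- compound 2 `NC(=O)[C@@H](CCC(F)(F)F)N(CC1CCCC1)S(=O)(=O)c1ccc(Cl)cc1` gives 6.01 10^-6 cm/s
- compound 3 `NC(=O)[C@@H](CCC(F)(F)F)N(C[C@@H]1CCCCO1)S(=O)(=O)c1ccc(Cl)cc1` gives 15.4 10^-6 cm/s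

Among these three, compound 3 cannot be separated from compound 1 (a 1.2-fold lower number from compound 1 to compound 3 (0.07 log units; within the scatter)), while it stands clear of compound 2 (a 2.6-fold higher number from compound 2 to compound 3 (0.41 log units; beyond the scatter)). The next compound, compound 4 `NC(=O)[C@@H](CCC(F)(F)F)N(C[C@@H]1CCCOC1)S(=O)(=O)c1ccc(Cl)cc1`, has not yet been measured. It has the same atoms as compound 3, joined differently: oxan-3-yl in place of oxan-2-yl on a saturated chain carbon bound to a sulfonamide nitrogen.

Among the compounds with values here, no measured step moves the oxygen within a ring, so the evidence is indirect. Exchanging 4,4-dimethyloxetan-2-yl for oxan-2-yl made no difference beyond the scatter (a 1.2-fold lower number from compound 1 to compound 3 (0.07 log units; within the scatter)). Only cyclopentyl, which carries no ring oxygen, produced modest steps (a 3.0-fold lower number from compound 1 to compound 2 (0.48 log units; beyond the scatter) and a 2.6-fold higher number from compound 2 to compound 3 (0.41 log units; beyond the scatter)). Compound 4 keeps a ring oxygen, so it is expected to stay with compound 1 and compound 3 rather than fall towards compound 2, with no change beyond the scatter. The expected step is a 1.2-fold lower number from compound 3 to compound 4 (0.07 log units; within the scatter) and it remains an estimate. The estimate for compound 4 is 13 10^-6 cm/s, with an expected range from 7 10^-6 cm/s to 22 10^-6 cm/s.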

Compound 4, apparent permeability: 18.4 10^-6 cm/s
The estimate for compound 4 lay 1.4-fold (0.15 log units) below the measured number; measured number inside the range.
By their numbers in this assay, from the lowest: compound 2; then compounds 3, 1 and 4 (each within the scatter of the next).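

In this assay, within the data shown here, the oxan-3-yl for oxan-2-yl swap on a saturated chain carbon bound to a sulfonamide nitrogen gives the first direct reading of a moved ring oxygen, and the step (a 1.2-fold higher number from compound 3 to compound 4 (0.08 log units; within the scatter)) does not separate the two isomers. The oxan-3-yl group also cannot be told apart from 4,4-dimethyloxetan-2-yl (a 1.0-fold higher number from compound 1 to compound 4 (0.01 log units; within the scatter)), while it stands clear of cyclopentyl (a 3.1-fold higher number from compound 2 to compound 4 (0.49 log units; beyond the scatter)), so compound 1, compound 3 and compound 4 now form one group, with compound 2 alone outside it and none of the four going against that split. Nothing measured here offers an explanation for this split.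

With cyclopentyl as the only ring lacking an oxygen, these compounds cannot show whether that oxygen is what sets compound 2 apart, or whether the split is specific to these ring groups. An oxan-4-yl ring, a morpholine ring or an open methoxyethyl chain at the same place would extend the comparison, as would the opposite stereocentre of the oxan-3-yl group.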